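Extending the ether chain from propyl to phenethyl

The compounds below may be only part of what the source reports. "The series", "measured", "known", "first", "only" and "open" are said of these compounds alone.

The series rests on a shared core carrying an ethoxy group in compound 1 `CCOc1ccc(OC)cc1CCCNC(C)=O` and a propoxy group in compound 2 `CCCOc1ccc(OC)cc1CCCNC(C)=O`. In an assay on CHO cells for displacement of a labelled ligand from melatonin receptor type 1B (Homo sapiens), read by scintillation counting, with a stated time of 60 min (a lower number here means a stronger inhibitor, a higher number a weaker inhibitor), compound 1 gives 1.59 nM, and compound 2 gives 2.12 nM. The step of a 1.3-fold higher number from compound 1 to compound 2 (0.12 log units; within the scatter) is the only one measured so far, and it places compound 2 at the higher number of the two, though the gap to compound 1 is within the scatter.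

Compound 3 `COc1ccc(OCCc2ccccc2)c(CCCNC(C)=O)c1` takes the same core further: phenyl in place of methyl on a saturated chain carbon, two bonds along the chain from an oxygen on an aromatic ring, so that propyl becomes phenethyl. Among the compounds with values here, the one step that bears on this, the step from compound 1 to compound 2, added a single carbon at the same place and moved the number hardly at all. Adding a phenyl there is a larger change, and no measured pair shows what a ring at this place does. The expectation for compound 3 is therefore a step of a 1.4-fold higher number from compound 2 to compound 3 (0.15 log units; within the scatter) that is small and uncertain in direction, with the chance of a weaker result growing with the size of the group. Compound 3 is estimated at 3 nM in this assay, with a range from 0.8 nM to 15 nM.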

Compound 3, inhibition constant: 13.4 nM
Compound 3: middle estimate off by 4.5-fold (0.65 log units), on the low side; measured number inside the range.
By their numbers in this assay, from the lowest: compounds 1 and 2 (each within the scatter of the next); then compound 3.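

The ring changes the picture at this place on the chain. The single carbon added earlier left the number within the scatter, but in this assay phenyl in place of methyl gives a 6.3-fold higher number from compound 2 to compound 3 (0.80 log units; beyond the scatter) and phenyl in place of hydrogen gives an 8.4-fold higher number from compound 1 to compound 3 (0.93 log units; beyond the scatter), both beyond the scatter. The position is therefore not indifferent to what it carries, although compound 3 still gives a measured inhibition constant of 13.4 nM in the nanomolar range. Nothing measured here accounts for the rise, and the numbers record only its size.

On these data alone, whether the rise belongs to the aromatic ring itself or simply to the larger group stays open, and a cyclohexyl in place of the phenyl or a longer saturated chain such as pentyl would help to separate the two. Also open, as far as these compounds go, is how a shorter link to the ring would read, as with benzyl in place of propyl, and whether a pyridine ring or an amine at the end of the chain would behave as the phenyl does.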